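A few compounds are considered here, and "the series" means these few. Any claim that something is new, unique, unknown or untested is made for them only; others in the source may bear on it.

Compound 1 `O=C(NCCCCc1ccccc1)n1cc(-c2ccccc2)oc1=O` is the reference point of this short series. Going by the values given here, in an assay on isolated protein for inhibition of acid ceramidase (Homo sapiens), read by LC-MS, with a stated time of 1 h (a higher number here means a weaker inhibitor, a lower number a stronger inhibitor), compound 1 gives 90 nM, the highest of the two numbers recorded; the only other measured member, compound 2 `O=C(NCCCCc1ccccc1)n1cc(-c2ccccn2)oc1=O`, gives 25 nM in this assay. Among the compounds with values here, the single measured step, a 3.6-fold lower number from compound 1 to compound 2 (0.56 log units; beyond the scatter), comes from pyridin-2-yl in place of phenyl on an aromatic carbon. The unmeasured compound 3 `CN1CCC(c2cn(C(=O)NCCCCc3ccccc3)c(=O)o2)CC1` differs from compound 1 by 1-methylpiperidin-4-yl in place of phenyl on an aromatic carbon, the new group sitting next to the ring oxygen of the shared core. Within the data shown here, no measured step covers a saturated, non-aromatic group at this position; the step from compound 1 to compound 2 shows only that the aromatic group at this place can be varied with a modest shift in this assay. A step for compound 3 of a 1.7-fold higher number from compound 1 to compound 3 (0.22 log units; within the scatter) is therefore expected, within a wide band. In this assay compound 3 is estimated at 150 nM, between 40 nM and 600 nM.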

Compound 3, half-maximal inhibitory concentration: 1400 nM
Compound 3: middle estimate off by 9.3-fold (0.97 log units), on the low side; the whole stated range lies below it.
By their numbers in this assay, from the lowest: compound 2; then compound 1; then compound 3.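

In this assay this position proves far less tolerant than the exchange between aromatic groups alone indicated: 1-methylpiperidin-4-yl in place of phenyl gives a 16-fold higher number from compound 1 to compound 3 (1.19 log units; beyond the scatter) and in place of pyridin-2-yl gives a 56-fold higher number from compound 2 to compound 3 (1.75 log units; beyond the scatter) with both steps beyond the scatter. Among these three compounds, the two six-membered aromatic rings give the lower numbers and the non-aromatic ring gives the highest, so a six-membered ring at this place is not enough to keep the number low. No measured data bear on the reason for this rise.

As far as these compounds go, whether the rise follows from losing the aromatic ring or from adding the ring nitrogen stays open; cyclohexyl, which has no ring nitrogen, and piperidin-4-yl without the methyl would separate these readings. From the compounds shown here alone, how a carboxylic acid or a longer chain at this place compares with phenyl also remains open.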